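This account rests on a few compounds, and the source may have more. Where it says the series, first, only, none or still open, it means among the compounds named here.

In an ADME assay on Vero cells (Chlorocebus sabaeus) for cytotoxicity, read by resazurin assay, with a stated time of 2 days (on this read-out higher numbers stand for lower toxicity in this test and lower numbers for higher toxicity in this test), compound 3 `CC(=O)OC[C@H]1O[C@@H](CC(=O)/C=C/c2cccc(NC(=O)Nc3ccccc3)c2)[C@@H](OC(C)=O)[C@@H](OC(C)=O)[C@@H]1OC(C)=O` gives 102000 nM, the smallest number among the three compounds measured, though its gap to compound 1 is within the scatter. Compound 1 `CC(=O)OC[C@H]1O[C@@H](CC(=O)/C=C/c2cccc(NC(=O)Nc3ccccc3)c2)[C@H](OC(C)=O)[C@@H](OC(C)=O)[C@@H]1OC(C)=O` gives 180000 nM, and compound 2 `CC(=O)OC[C@H]1O[C@@H](CC(=O)/C=C/c2cccc(NS(=O)(=O)c3ccc(C)cc3)c2)[C@H](OC(C)=O)[C@@H](OC(C)=O)[C@@H]1OC(C)=O` gives 584000 nM. Compound 1 and compound 3 differ only in configuration as drawn (the fact that compounds 1 and 3 differ only in the configuration as drawn), and that step reads a 1.8-fold lower number from compound 1 to compound 3 (0.25 log units; within the scatter). Compound 4 `CC(=O)OC[C@H]1O[C@@H](CC(=O)/C=C/c2cccc(NS(=O)(=O)c3ccc(C)cc3)c2)[C@@H](OC(C)=O)[C@@H](OC(C)=O)[C@@H]1OC(C)=O` carries the change ((4-methylphenyl)sulfonyl in place of phenylcarbamoyl on a nitrogen on an aromatic ring). The same change has been measured once, on another drawing of the sugar: a 3.2-fold higher number from compound 1 to compound 2 (0.51 log units; beyond the scatter). A step of about that size and direction is therefore expected here, a 3.1-fold higher number from compound 3 to compound 4 (0.50 log units; beyond the scatter). Compound 4 is expected to give about 320000 nM in this assay, with a range from 150000 nM to 680000 nM.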

Compound 4, half-maximal cytotoxic concentration: 123000 nM
Compound 4: the middle estimate sits 2.6-fold (0.42 log units) above what was measured; the measured number lies below the stated range.
By their numbers in this assay, from the lowest: compounds 3, 4 and 1 (each within the scatter of the next); then compound 2.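

In this assay the change of phenylcarbamoyl to (4-methylphenyl)sulfonyl on a nitrogen on an aromatic ring reads a 1.2-fold higher number from compound 3 to compound 4 (0.08 log units; within the scatter), so the size of this step depends on the configuration drawn at the saturated ring carbon: the same change on two cores in this assay, a 3.2-fold higher number (0.51 log units; beyond the scatter) from compound 1 to compound 2 and a 1.2-fold higher number (0.08 log units; within the scatter) from compound 3 to compound 4, 2.7-fold (0.43 log units) apart, beyond the scatter of two such steps. The same configuration change, which stayed within the scatter in the phenylcarbamoyl pair, now gives a 4.7-fold lower number from compound 2 to compound 4 (0.68 log units; beyond the scatter) in the sulfonyl pair: the fact that compounds 2 and 4 differ only in the configuration as drawn. The compounds shown leave open whether an acetyl or a methylsulfonyl group on that nitrogen would show the same dependence on configuration, and whether free hydroxyl groups in place of the acetate esters would.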